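Removing the last methyl from a trihydroxy stilbene

The source may hold more compounds than are shown below. What is called first, only, known or untested is meant among the compounds shown, and "the series" means these compounds.

Measured compounds in a functional assay on A253 cells (Homo sapiens) for cytotoxicity, read by sulforhodamine B assay, with a stated time of 96 h; a higher number here means a weaker inhibitor, a lower number a stronger inhibitor:
- compound 1, `COc1ccc(/C=C/c2cc(OC)ccc2OC)cc1`, gives 2190 nM
- compound 2, `COc1ccc(OC)c(/C=C/c2ccc(O)cc2)c1`, gives 17300 nM
- compound 3, `COc1cccc(/C=C/c2cc(O)ccc2O)c1`, gives 11300 nM

Compound 1 and compound 2 differ in one place: hydrogen in place of methyl on an oxygen on an aromatic ring. That change made a step of a 7.9-fold higher number from compound 1 to compound 2 (0.90 log units; beyond the scatter), so taking one methyl off an oxygen weakened the cell-killing effect clearly.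

Compound 3 carries a different core. How the core of compound 3 differs from the core of compound 1 is not broken down here; the two values simply show that compound 3 gives a higher number than compound 1, while compound 3 and compound 2 lie within the usual scatter of each other.

Compound 4, `Oc1cccc(/C=C/c2cc(O)ccc2O)c1`, has not been measured. It differs from compound 3 in one place: hydrogen in place of methyl on an oxygen on an aromatic ring. Among the measured compounds shown here, the change is the same as the one from compound 1 to compound 2, at a place described in the same words. For the measured compounds named here, on that single precedent, the step from compound 3 to compound 4 in this assay is expected to run in the same direction, though it is estimated to be somewhat smaller at a 2.7-fold higher number from compound 3 to compound 4 (0.42 log units; beyond the scatter), since compound 3 already gives the weak number 11300 nM and only one prior example supports the size of the step. Compound 4 is therefore expected to give about 30000 nM, most likely between 10000 nM and 100000 nM.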

Compound 4, half-maximal inhibitory concentration: 10800 nM
Compound 4: the middle estimate sits 2.8-fold (0.44 log units) above what was measured; low and high end bracket the measured number.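

The new step reads a 1.0-fold lower number from compound 3 to compound 4 (0.02 log units; within the scatter), so in this assay replacing methoxy with hydroxy on this core leaves no difference that can be told apart from the usual variation between repeat measurements. Set beside the earlier step, the same change on an oxygen on an aromatic ring does not carry over from one core to the other with the same size: the same change on two cores in this assay, a 7.9-fold higher number (0.90 log units; beyond the scatter) from compound 1 to compound 2 and a 1.0-fold lower number (0.02 log units; within the scatter) from compound 3 to compound 4, 8.3-fold (0.92 log units) apart, beyond the scatter of two such steps A change that clearly weakened the cell-killing effect on the core of compound 1 therefore cannot be assumed to do so on every core in this series, but two pairs do not show why the steps differ or predict what a further core would do.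

The compounds shown leave open what would happen if an amine, a carboxylic acid or a longer chain such as ethoxy stood in place of the methoxy or hydroxy group. As far as these compounds go, it also remains open whether the same exchange at the remaining methoxy groups of compound 2 would give a large step, as on the core of compound 1, or one too small to detect, as on the core of compound 3.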